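Compound 4 and the 4,5-Dimethyl-1H-imidazol-2-yl Group

The source may hold more compounds than are shown below. What is called first, only, known or untested is meant among the compounds shown, and "the series" means these compounds.

Of the compounds shown here, three sharing one core have been measured so far in an ADME assay on microsomes from liver (Mus musculus) for metabolic stability; on this read-out higher numbers stand for a longer-lived compound and lower numbers for a shorter-lived compound. Compound 1 `CC(C)C(c1ccc(-c2ccc3cccc(F)c3c2)[nH]c1=O)N1CCCCS1(=O)=O` gives 0.0733 h and sits at the low end of the three, together with compound 2 `CC(C)C(c1ccc(-c2ccc3cccc(F)c3c2)[nH]c1=O)N1CCCCC1=O` at 0.0967 h and within the scatter of it. Compound 3 `CC(C)C(c1ccc(-c2ccc3cccc(F)c3c2)[nH]c1=O)N1CCN/C1=N\C#N` stands apart from both at 0.207 h and is the longest-lived of the set.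

The unmeasured compound 4 `Cc1nc(C(c2ccc(-c3ccc4cccc(F)c4c3)[nH]c2=O)C(C)C)[nH]c1C` keeps the core of compound 1 and changes one group: a group of 7 heavy atoms (5 carbon, 2 nitrogen; one five-membered aromatic ring with 2 hetero atoms) in place of a group of 8 heavy atoms (4 carbon, 1 nitrogen, 2 oxygen, 1 sulfur; one six-membered non-aromatic ring with 2 hetero atoms), on a saturated chain carbon bound to an aromatic carbon and a saturated chain carbon. The entering ring is aromatic, unlike the rings at this place in the three measured compounds.

Three measured steps at this same place bear on the change. They are a 1.3-fold higher number from compound 1 to compound 2 (0.12 log units; within the scatter) and a 2.8-fold higher number from compound 1 to compound 3 (0.45 log units; beyond the scatter) with a 2.1-fold higher number from compound 2 to compound 3 (0.33 log units; beyond the scatter) as the third. Among the compounds with values here, only the step to compound 3 (0.207 h) left the scatter from compound 1, and no measured compound carries an aromatic ring here, so these steps are a rough guide only. A small upward step within the scatter is therefore expected. The step estimated is a 1.6-fold higher number from compound 1 to compound 4 (0.21 log units; within the scatter) in this assay by this reasoning. The estimate for compound 4 is 0.12 h with 0.06 h to 0.25 h as the expected range.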

Compound 4, half-life: 0.0817 h
Estimate against measurement, compound 4: 1.5-fold (0.17 log units) above; the measured number falls inside the stated range.
By their numbers in this assay, from the lowest: compounds 1, 4 and 2 (each within the scatter of the next); then compound 3.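

In this assay the 4,5-dimethyl-1H-imidazol-2-yl group, the first aromatic ring at this place, does not separate compound 4 from the two six-membered rings: the data give a 1.1-fold higher number from compound 1 to compound 4 (0.05 log units; within the scatter) and a 1.2-fold lower number from compound 2 to compound 4 (0.07 log units; within the scatter) and both steps stay within the scatter. Against the other five-membered ring the data give a 2.5-fold lower number from compound 3 to compound 4 (0.40 log units; beyond the scatter) and this step lies beyond the scatter, so compound 3 now stands apart from all three other compounds, and among these four compounds neither ring size nor the presence of an aromatic ring alone tracks the half-life. Nothing in the data accounts for these numbers.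

On these data alone, how far the two methyl groups of the 4,5-dimethyl-1H-imidazol-2-yl group bear on the number stays open, and an unsubstituted imidazol-2-yl ring or a pyridine ring at this place would be needed to test that and to show whether other aromatic rings behave alike. Also open, as far as these compounds go, is which feature of the ring in compound 3 goes with its longer half-life, a question that a comparison with a plain imidazolidin-2-one ring could narrow.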